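Nitro for bromo on a benzothiazolyl acylthiourea core

The compounds below may be only part of what the source reports. "The series", "measured", "known", "first", "only" and "open" are said of these compounds alone.

Measured so far:
compound 1 `CCCCC(=O)NC(=S)Nc1nc2cc([N+](=O)[O-])ccc2s1` — > 100000 nM
compound 2 `O=C(NC(=S)Nc1nc2cc(Br)ccc2s1)N1CCOCC1` — 18100 nM
compound 3 `O=C(NC(=S)Nc1nc2cc(Br)ccc2s1)c1cccs1` — 24200 nM

Three compounds share a core and were tested in a functional assay on MCF7 cells (Homo sapiens) for cytotoxicity, read by MTT assay, with a stated time of 24 h; on this read-out higher numbers stand for weaker inhibition and lower numbers for stronger inhibition. Compound 1 gives only a limit, > 100000 nM, and not a number. Compound 2 gives 18100 nM, the lowest of the two numbers shown. Compound 3 gives 24200 nM, and the step of a 1.3-fold higher number from compound 2 to compound 3 (0.13 log units; within the scatter) stays within the scatter, so no order between compound 2 and compound 3 can be read from it.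

Compound 4 `O=C(NC(=S)Nc1nc2cc([N+](=O)[O-])ccc2s1)N1CCOCC1` differs from compound 2 in one place: nitro in place of bromo on an aromatic carbon. Among the measured compounds shown here, no measured step isolates this exchange. For the measured compounds named here, the one measured step, a 1.3-fold higher number from compound 2 to compound 3 (0.13 log units; within the scatter), concerns the carbonyl substituent and says nothing about the halogen position. Going by the values given here, compound 1 also carries nitro, but its acyl group differs as well and its value is a limit, so it offers no step either. The expectation for compound 4 in this assay therefore rests on compound 2 alone, with added uncertainty from compound 1 sitting at the limit of > 100000 nM in this assay, at which 1 of the 3 values shown sits. Compound 4 is expected to give 40000 nM, within 12000 nM to 150000 nM, a step of a 2.2-fold higher number from compound 2 to compound 4 (0.34 log units; beyond the scatter) that is estimated as a weakening.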

Compound 4, half-maximal inhibitory concentration: 31000 nM
For compound 4 the middle estimate is 1.3-fold (0.11 log units) above the measured one; the range from low to high includes it.
By their numbers in this assay, from the lowest: compounds 2, 3 and 4 (each within the scatter of the next). At a limit, above all of these: compound 1.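

In this assay, the exchange at this aromatic carbon can now be read directly, with morpholin-4-yl held on the carbonyl carbon: the step is a 1.7-fold higher number from compound 2 to compound 4 (0.23 log units; within the scatter), so nitro in place of bromo gives no change that can be told from the scatter. With nitro held instead, the carbonyl substituent does matter, since morpholin-4-yl in place of butyl gives an at least 3.2-fold lower number from compound 1 to compound 4 (0.50 log units; beyond the scatter). The value of compound 1 in that step is a limit and not a number: the limit of > 100000 nM in this assay, at which 1 of the 4 values shown sits.

The compounds shown leave open whether an amine or a carboxylic acid on this aromatic carbon would also stay within the scatter of compound 2. They also leave open whether nitro in place of bromo reads the same with thiophen-2-yl or butyl on the carbonyl carbon.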